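This account rests on a few compounds, and the source may have more. Where it says the series, first, only, none or still open, it means among the compounds named here.

Measured so far:
- compound 1 `O=C(Nc1ccc(S(=O)(=O)N2CCCC2)cc1)c1ccc(CCl)cc1`: in an ADME assay on Vero cells (Chlorocebus sabaeus) for cytotoxicity, read by MTT assay (a higher number here means that more compound is tolerated, a lower number that less compound is tolerated), compound 1 gives 11000 nM
- compound 2 `Cn1nc(C(F)(F)F)cc1C(=O)Cc1ccc(S(=O)(=O)N2CCCC2)cc1`: compound 2 gives > 300000 nM, which is a limit of the assay and not a number
- compound 3 `Cn1nc(C(F)(F)F)cc1C(=O)Nc1ccc(S(=O)(=O)N2CCC[C@H]2C(=O)OCc2ccccc2)cc1`: compound 3 gives 100000 nM

Among the two numbers that are not limits, compound 3 carries the highest one; the nearest is compound 1, and the gap between them lies beyond the usual scatter of repeated measurements. Compound 2 sits at the limit described in the limit of > 300000 nM in this assay, at which 1 of the 3 values shown sits, so its place relative to compound 3 cannot be told from a number.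

Compound 4 `Cn1nc(C(F)(F)F)cc1C(=O)Nc1ccc(S(=O)(=O)N2CCC[C@H]2C(=O)O)cc1` is built from compound 3 by one change: hydrogen in place of benzyl on an oxygen next to a carbonyl group. Spelled out, that is hydrogen in place of benzyl on an oxygen next to a carbonyl group. Among the measured compounds shown here, no pair of measured compounds shows this exact change, so its effect has not been seen in this set.

With compound 3 already tolerated at a high concentration, the expectation for compound 4 in this assay is a step from compound 3 to compound 4 of a 2.0-fold higher number from compound 3 to compound 4 (0.30 log units; within the scatter), upward or nothing beyond the scatter, and a fair chance that only a limit is reported. The estimated value for compound 4 is 200000 nM, with a range from 70000 nM to 600000 nM.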

Compound 4, half-maximal cytotoxic concentration: > 300000 nM
Compound 4 gave a limit, no number; the forecaster's own chance of this, stated with the estimate: 40%; middle value at least 1.5-fold (0.17 log units) away from the limit.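

In this assay, replacing benzyl with hydrogen on an oxygen next to a carbonyl group, which turns benzyloxycarbonyl into carboxy, gives an at least 3.0-fold higher number from compound 3 to compound 4 (0.47 log units; beyond the scatter). Among the compounds shown here, this is the first pair in the set that differs in only one place, so it is the first direct view of how this position affects the amount of compound the cells tolerate, and losing the benzyl group with its six-membered aromatic ring moves the result upward rather than downward. Compound 4 gives > 300000 nM, which is a limit of the assay and not a number, so the step marks only a minimum and its full size stays hidden, and the top of the range now holds more of the values: the limit of > 300000 nM in this assay, at which 2 of the 4 values shown sit.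

A single pair cannot show whether the change depends on losing the benzyl group or on gaining the free carboxylic acid, and a methyl ester or a primary amide at this place could help to separate the two. On these data alone, it also remains open whether the same change would read the same way on a different core or in another cell type.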